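Ring substitution and minimum effective dose in the series

The compounds below may be only part of what the source reports. "The series", "measured", "known", "first", "only" and "open" are said of these compounds alone.

Compound 1 `CCc1cccc2c(=O)c(-c3nn[nH]n3)c[nH]c12` gives in a functional assay on the whole organism (strain Sprague-Dawley) for inhibition, with Rattus norvegicus as the target (on this read-out lower numbers stand for an effect already at smaller amounts and higher numbers for an effect only at larger amounts of compound), only a limit, > 25 mg/kg.
Compound 2 `O=c1c(-c2nn[nH]n2)c[nH]c2c(Br)cccc12` gives in this assay only a limit, > 10 mg/kg.
Compound 3 `O=c1c(-c2nn[nH]n2)c[nH]c2ccccc12` gives in this assay only a limit, > 20 mg/kg.

Compound 3 thus stands at a limit, and the two other values shown are limits as well. The steps a step that the two limits leave unreadable from compound 1 to compound 3, a step that the two limits leave unreadable from compound 2 to compound 3 and a step that the two limits leave unreadable from compound 1 to compound 2 therefore cannot be sized; the limits (the limit of > 25 mg/kg in this assay, at which 1 of the 3 values shown sits), the limit of > 20 mg/kg in this assay, at which 1 of the 3 values shown sits, and the limit of > 10 mg/kg in this assay, at which 1 of the 3 values shown sits, leave them open. Compound 4 `O=c1c(-c2nn[nH]n2)c[nH]c2ccc(Cl)cc12` differs from compound 3 by chloro in place of hydrogen on an aromatic carbon. The steps from compound 1 and compound 2 to compound 3 concern substitution on the same ring and are the only ones that bear on this change, but none is readable, so no step beyond the scatter can be expected in this assay. The expected step that the limit leaves unreadable from compound 3 to compound 4 is small. Compound 4 is expected at 25 mg/kg, within 10 mg/kg to 60 mg/kg, most likely again as a limit.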

Compound 4, minimum effective dose: > 25 mg/kg
Compound 4: a limit, no number; the forecaster's own chance of this, stated with the estimate: 70%; the middle value lies on the limit itself.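

Compound 4 gives only a limit in this assay, > 25 mg/kg; compound 3 also stands at a limit, so the step between them cannot be read. The compounds shown leave open whether ethyl, bromo, chloro or hydrogen changes the minimum effective dose.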